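The source may report more compounds than this note shows. Statements on the series, on what has been measured and on what is new or still open speak of the compounds shown alone.

Compounds measured so far:
- compound 1 `O=C(COc1ccc2c(=O)ccoc2c1)Nc1cccc(NC(=O)c2ccc(OC(F)(F)F)cc2)c1`: 869 nM
- compound 2 `O=C(COc1ccc2c(=O)ccoc2c1)Nc1cccc(NC(=O)c2cnc(C(F)(F)F)s2)c1`: 160 nM

Both numbers come from an assay on isolated protein for inhibition of Rho-associated protein kinase 1 (Homo sapiens), read by scintillation counting, radiometric assay and 33P incorporation, with a stated time of 40 min, in the presence of a further agent that is not named here; a higher number here means a weaker inhibitor, a lower number a stronger inhibitor. Among the compounds with values here, of the two, compound 2 gives the lower number, and the one step that links them, a 5.4-fold lower number from compound 1 to compound 2 (0.73 log units; beyond the scatter), lies beyond the scatter.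

Compound 3 `Nc1ccc(C(=O)Nc2cccc(NC(=O)COc3ccc4c(=O)ccoc4c3)c2)cc1` has not yet been measured in this assay. It differs from compound 2 in one place: 4-aminophenyl in place of 2-(trifluoromethyl)-1,3-thiazol-5-yl on a carbonyl carbon.

Within the data shown here, only one measured step bears on this change, and it does so indirectly. In going from compound 1 to compound 2 a phenyl ring carrying a trifluoromethoxy group was exchanged for the thiazole, and the number fell by a 5.4-fold lower number from compound 1 to compound 2 (0.73 log units; beyond the scatter). Compound 3 goes back to a phenyl ring, now carrying an amino group instead. Among the measured compounds shown here, no measured pair shows what an amino group on that ring does, so the size of the step is uncertain. Because the thiazole was the better of the two groups seen in a 5.4-fold lower number from compound 1 to compound 2 (0.73 log units; beyond the scatter), returning to a phenyl ring is expected to give a higher number, of modest size: a 3.1-fold higher number from compound 2 to compound 3 (0.49 log units; beyond the scatter). For compound 3 the expected value is 500 nM, within a range of 150 nM to 1700 nM.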

Compound 3, half-maximal inhibitory concentration: 802 nM
Compound 3: middle estimate off by 1.6-fold (0.21 log units), on the low side; low and high end bracket the measured number.
By their numbers in this assay, from the lowest: compound 2; then compounds 3 and 1 (each within the scatter of the next).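

In this assay, the change from the thiazole to a second phenyl ring gives a 5.0-fold higher number from compound 2 to compound 3 (0.70 log units; beyond the scatter), so the lower number of compound 2 does not depend on comparison with the trifluoromethoxy compound alone. Within the data shown here, on the phenyl ring itself, amino in place of trifluoromethoxy gives a 1.1-fold lower number from compound 1 to compound 3 (0.03 log units; within the scatter), which lies within the scatter; these two quite different groups therefore cannot be told apart here, and among the three compounds only the one with 2-(trifluoromethyl)-1,3-thiazol-5-yl on the carbonyl carbon stands apart from the others. Nothing available here accounts for that difference.

The compounds shown leave open whether the lower number belongs to the thiazole ring or to its trifluoromethyl group, a question that a thiazole carrying a methyl group, or a phenyl ring carrying trifluoromethyl, would help to settle. They also leave open whether any group on the phenyl ring can move the number, for example a carboxylic acid or a nitrile, given that the two groups seen there gave numbers within the scatter of each other.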